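A few compounds are considered here, and "the series" means these few. Any claim that something is new, unique, unknown or untested is made for them only; others in the source may bear on it.

Working notes on the series. Compound 2 `CC#CCn1c(N2CCC[C@@H](N)C2)cc(=O)n(Cc2cc(F)cc(F)c2)c1=O` stands highest of the two numbers in a physicochemical assay for lipophilicity; a lower number here means a more polar compound, a higher number a more lipophilic compound: compound 2 gives 2.12, while compound 1 `CC#CCn1c(N2CCC[C@@H](N)C2)cc(=O)n(Cc2ccc(OC)c(OC)c2)c1=O` gives 1.55. Among the compounds with values here, the one measured step, a number 0.57 log units higher from compound 1 to compound 2 (beyond the scatter), swaps one aryl group for another and so bears only loosely on the change to compound 3 `CC#CCn1c(N2CCC[C@@H](N)C2)cc(=O)n(CCCCCC)c1=O`, which is pentyl in place of 3,5-difluorophenyl on a saturated chain carbon bound to an aromatic nitrogen. Exchange of an aryl group for a chain of this length leaves no clear lead; no step beyond the scatter is expected, so a number 0.02 log units lower from compound 2 to compound 3 (within the scatter) is the estimate. In this assay compound 3 is expected to give 2.1, between 1.7 and 2.5.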

Compound 3, partition coefficient: 2.15
Beside the measured number, compound 3's estimate is 0.05 log units below it; measured number inside the range.
By their numbers in this assay, from the lowest: compound 1; then compounds 2 and 3 (each within the scatter of the next).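

In this assay, an open chain on a saturated chain carbon bound to an aromatic nitrogen gives a number 0.03 log units higher from compound 2 to compound 3 (within the scatter) with pentyl in place of 3,5-difluorophenyl, so an aromatic ring is not required here to reach this number. Pentyl in place of 3,4-dimethoxyphenyl gives a number 0.60 log units higher from compound 1 to compound 3 (beyond the scatter) and leaves compound 1 lowest of the three. Nothing on hand accounts for either step. Open, going by these compounds, is how a longer chain such as octyl, or a chain ending in an amine or a carboxylic acid, would read at this position.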